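From Nitro to Methoxy: What the Numbers Suggest

A few compounds are considered here, and "the series" means these few. Any claim that something is new, unique, unknown or untested is made for them only; others in the source may bear on it.

Of the compounds shown here, two sharing one core have been measured in a functional assay on PC-3 cells (Homo sapiens) for inhibition, read by MTT assay, with a stated time of 72 h; on this read-out higher numbers stand for weaker inhibition and lower numbers for stronger inhibition. Compound 1 `O=C(CSc1nc(Nc2ccccc2)c2ccccc2n1)Nc1cccc(Br)c1` gives 11400 nM in this assay. Compound 2 `O=C(CSc1nc(Nc2ccccc2)c2ccccc2n1)Nc1cccc([N+](=O)[O-])c1` gives 11800 nM. Within the data shown here, the single step between them, a 1.0-fold higher number from compound 1 to compound 2 (0.01 log units; within the scatter), exchanges bromo for nitro and leaves the read-out essentially where it was. Compound 2 therefore stands at the higher of the two numbers, but within the scatter of compound 1.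

Compound 3 `COc1cccc(NC(=O)CSc2nc(Nc3ccccc3)c3ccccc3n2)c1` is the next candidate. Its change from compound 2 is methoxy in place of nitro on an aromatic carbon. Among the measured compounds shown here, no measured step involves a methoxy, so the only evidence bearing on it is a 1.0-fold higher number from compound 1 to compound 2 (0.01 log units; within the scatter), which shows one substituent exchange on this ring leaving the number unchanged. A step of similar size, none beyond the scatter, is expected here, in either direction. Compound 3 is thus estimated at 11000 nM, with a range from 5000 nM to 25000 nM. The expected step is a 1.1-fold lower number from compound 2 to compound 3 (0.03 log units; within the scatter).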

Compound 3, half-maximal inhibitory concentration: 11600 nM
Estimate against measurement, compound 3: 1.1-fold (0.02 log units) below; the measured number falls inside the stated range.
By their numbers in this assay, from the lowest: compounds 1, 3 and 2 (each within the scatter of the next).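

In this assay the exchange of nitro for methoxy gives a 1.0-fold lower number from compound 2 to compound 3 (0.01 log units; within the scatter) and the exchange of bromo for methoxy gives a 1.0-fold higher number from compound 1 to compound 3 (0.01 log units; within the scatter) and neither step leaves the scatter. Bromo, nitro and methoxy on this aromatic carbon, meta to a large group, therefore give numbers that cannot be told apart, whereas the earlier pair offered only bromo and nitro and no group joined through oxygen. No measured evidence is available to explain this flat read-out.

The compounds shown leave open whether any group at this place can move the number beyond the scatter, such as an amine, a carboxylic acid or a longer chain in place of methoxy. They also leave open whether these three groups would remain as alike elsewhere on the shared core.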